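The compounds below may be only part of what the source reports. "The series", "measured", "known", "first", "only" and "open" are said of these compounds alone.

Measured so far in an in vitro ADME assay on microsomes from liver (Rattus norvegicus) for pharmacokinetics; on this read-out lower numbers stand for slow clearance and higher numbers for fast clearance:
compound 1 `Nc1nc(C(F)(F)F)cc2c1[nH]c(=O)n2Cc1ccc(NCCN2CCCCC2)nc1` gives 16 mL.min-1.g-1;
compound 2 `CN1CCN(c2ccc(Cn3c(=O)[nH]c4c(N)nc(C(F)(F)F)cc43)cn2)CC1` gives 46 mL.min-1.g-1;
compound 3 `CN(C)CCNc1ccc(Cn2c(=O)[nH]c3c(N)nc(C(F)(F)F)cc32)cn1` gives 16 mL.min-1.g-1.

Compound 2 stands highest of the three in this assay. Compound 4 `CN1CCN(CCN(C)c2ccc(Cn3c(=O)[nH]c4c(N)nc(C(F)(F)F)cc43)cn2)CC1` is not yet measured; it differs from compound 2 by methyl(2-(4-methylpiperazin-1-yl)ethyl)amino in place of 4-methylpiperazin-1-yl on an aromatic carbon. Among the compounds with values here, two measured steps bear on this. Replacing the 4-methylpiperazin-1-yl by a chain-linked amine gave a 2.9-fold lower number from compound 2 to compound 3 (0.46 log units; beyond the scatter), and the reverse comparison gave a 2.9-fold higher number from compound 1 to compound 2 (0.46 log units; beyond the scatter). Compound 4 also carries a chain-linked amine, yet it keeps the 4-methylpiperazin-1-yl at the chain's end, so a smaller drop than from compound 2 to compound 3 is expected. For compound 4 a step of a 1.6-fold lower number from compound 2 to compound 4 (0.22 log units; within the scatter) is expected, giving an estimate of 28 mL.min-1.g-1 with a range from 12 mL.min-1.g-1 to 65 mL.min-1.g-1.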

Compound 4, intrinsic clearance in microsomes: 15 mL.min-1.g-1
Estimate against measurement, compound 4: 1.9-fold (0.27 log units) above; low and high end bracket the measured number.
By their numbers in this assay, from the lowest: compounds 4, 1 and 3 (each within the scatter of the next); then compound 2.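

Moving the 4-methylpiperazin-1-yl out on a chain, as methyl(2-(4-methylpiperazin-1-yl)ethyl)amino, gave a 3.1-fold lower number from compound 2 to compound 4 (0.49 log units; beyond the scatter), so that ring being present does not by itself go with the high number. Both a 1.1-fold lower number from compound 3 to compound 4 (0.03 log units; within the scatter) and a 1.1-fold lower number from compound 1 to compound 4 (0.03 log units; within the scatter) lie within the scatter, so the three chain-linked amines cannot be told apart, whatever the amine at the chain's end. Among these compounds, only compound 2, with the ring attached directly to the aromatic carbon, stands apart.

Nothing shown explains this difference. As far as these compounds go, whether it extends to other directly attached rings stays open, and a morpholin-4-yl on the same aromatic carbon would test that.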